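The compounds below may be only part of what the source reports. "The series", "measured", "known", "first", "only" and "open" are said of these compounds alone.

Going by the values given here, the series shares one core, carried unchanged through compound 1 `Cc1ccc(C)c(NC(=O)c2ccc(/N=N\c3c[nH]c4ccccc34)cc2)c1` and compound 2 `O=C(Nc1ccccc1F)c1ccc(/N=N\c2c[nH]c3ccccc23)cc1`; the only variation so far is the aryl group on the amide-type nitrogen. In a functional assay on HCT-116 cells (Homo sapiens) for inhibition, read by MTT assay, with a stated time of 72 h (a higher number here means a weaker inhibitor, a lower number a stronger inhibitor), compound 1 gives 544000 nM, and in this assay compound 2 gives 559000 nM. Among the compounds with values here, compound 2 and compound 1 lie within the scatter of each other, so the two numbers cannot be separated; the single measured step, a 1.0-fold higher number from compound 1 to compound 2 (0.01 log units; within the scatter), is the whole of what the data show about swapping this aryl group.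

Compound 3 `O=C(Nc1ccc(Cl)cc1)c1ccc(/N=N\c2c[nH]c3ccccc23)cc1` is not yet measured. Against compound 2 the change is 4-chlorophenyl in place of 2-fluorophenyl on an amide-type nitrogen. Within the data shown here, the one step that bears on it is the same kind of exchange at the same nitrogen, and it read a 1.0-fold higher number from compound 1 to compound 2 (0.01 log units; within the scatter), within the scatter. On that basis no movement beyond the scatter in this assay is expected, in either direction; the step from compound 2 to compound 3 is estimated as a 1.0-fold lower number from compound 2 to compound 3 (0.01 log units; within the scatter). For compound 3 the expected value in this assay is 550000 nM, with a range of 250000 nM to 1200000 nM.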

Compound 3, half-maximal inhibitory concentration: 187000 nM
Compound 3: the middle estimate sits 2.9-fold (0.47 log units) above what was measured, outside the stated range (below it).
By their numbers in this assay, from the lowest: compound 3; then compounds 1 and 2 (each within the scatter of the next).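

In this assay the aryl group on the amide-type nitrogen is no longer silent: 4-chlorophenyl in place of 2-fluorophenyl gives a 3.0-fold lower number from compound 2 to compound 3 (0.48 log units; beyond the scatter) and 4-chlorophenyl in place of 2,5-dimethylphenyl gives a 2.9-fold lower number from compound 1 to compound 3 (0.46 log units; beyond the scatter) while the two earlier groups could not be separated. Compound 3 is therefore the strongest inhibitor of the three, with both of its steps beyond the scatter, yet the steps are modest and compound 3 still gives 187000 nM in this assay. The exchange from 2-fluorophenyl to 4-chlorophenyl alters both the halogen and its numbered place on the ring in a single step, and nothing available bears on why the number falls.

The compounds shown leave open whether chlorine or its place carries the step, a question that 4-fluorophenyl and 2-chlorophenyl would address directly. They also leave open how this aryl group responds to a methoxy group, an amine or a carboxylic acid, and whether the step holds when the shared core itself is changed.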